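Methoxy to fluoro swap in the nitrogen-rich aryl series

This account rests on a few compounds, and the source may have more. Where it says the series, first, only, none or still open, it means among the compounds named here.

Measured compounds in an ADME assay on Huh-7 cells (Homo sapiens) for cytotoxicity; a lower number here means that less compound is tolerated, a higher number that more compound is tolerated:
compound 1, `CN1CCN(CCCNCc2cn(-c3ccc([N+](=O)[O-])cc3)nc2-c2ccc(OC(F)(F)F)cc2)CC1`, gives 1600 nM
compound 2, `CN1CCN(CCNCc2cn(-c3ccc([N+](=O)[O-])cc3)nc2-c2ccc(C(F)(F)F)cc2)CC1`, gives 3200 nM
compound 3, `COc1ccc(-n2cc(CNCCN3CCN(C)CC3)c(-c3ccccc3C)n2)cc1`, gives > 20000 nM

Compound 1 and compound 2 both return numbers in this assay. For compound 3 the readout is a limit of the assay rather than a number: the limit of > 20000 nM in this assay, at which 1 of the 3 values shown sits. So compound 3 stands at the tolerant end of the three values shown, and only its lower bound is known.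

Compound 4, `Cc1ccccc1-c1nn(-c2ccc(F)cc2)cc1CNCCN1CCN(C)CC1`, is the next compound to be run in this assay. It differs from compound 3 in one place: fluoro in place of methoxy on an aromatic carbon. Among the measured compounds shown here, no step between measured compounds covers this change, so the expectation rests on the size of the change alone. A single small group swapped for another small group on the same aromatic carbon is expected to move the value by no more than the usual scatter, in no particular direction, which is what a step that the limit leaves unreadable from compound 3 to compound 4 is meant to express. Compound 4 is therefore estimated at 25000 nM in this assay, with a range from 8000 nM to 70000 nM, and a fair chance that the assay again reports only a limit.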

Compound 4, half-maximal cytotoxic concentration: > 20000 nM
Compound 4: a limit, no number (the forecaster's own chance of this, stated with the estimate: 60%); the middle value does not contradict the limit.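

No step from compound 3 to compound 4 can be read, since both compounds stand at a limit of the assay: the limit of > 20000 nM in this assay, at which 2 of the 4 values shown sit.

The compounds shown leave open whether fluoro in place of methoxy on an aromatic carbon changes the value at all.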